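Compound 4: methoxypyridinyl in place of methoxyphenyl

The source may report more compounds than this note shows. Statements on the series, on what has been measured and on what is new or still open speak of the compounds shown alone.

Compound 1 `C=CC[C@H]1C[C@]2([C@@H](C)Cc3ccc(OC)c(OC)c3)OCOC2=CC1=O` anchors the set; in a functional assay on M14 cells (Homo sapiens) for antiproliferative activity, with a stated time of 72 h (on this read-out higher numbers stand for weaker inhibition and lower numbers for stronger inhibition), compound 1 gives 110 nM. Compound 2 `C=CC[C@@H]1C[C@]2([C@H](C)Cc3ccc(OC)c(OC)c3)OCOC2=CC1=O` has the same atoms and bonds in a different drawn configuration. In this assay compound 2 reaches a limit of > 4000 nM, which is a limit of the assay and not a number. The step of an at least 36-fold higher number from compound 1 to compound 2 (1.56 log units; beyond the scatter) rests on the fact that compounds 1 and 2 differ only in the configuration as drawn and on (the limit of > 4000 nM in this assay, at which 1 of the 3 values shown sits). Compound 3 `C=CC[C@H]1C[C@]2([C@@H](C)Cc3cccc(OC)c3)OCOC2=CC1=O` lacks one methoxy group, and in this assay compound 3 gives 8800 nM, the highest of the two numbers, with compound 1 the nearest; the step is an 80-fold higher number from compound 1 to compound 3 (1.90 log units; beyond the scatter).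

Compound 4 `C=CC[C@H]1C[C@]2([C@@H](C)Cc3ccc(OC)nc3)OCOC2=CC1=O` differs from compound 3 by 6-methoxypyridin-3-yl in place of 3-methoxyphenyl on a saturated chain carbon, two bonds along the chain from a saturated ring carbon. Neither measured step covers this exchange: an at least 36-fold higher number from compound 1 to compound 2 (1.56 log units; beyond the scatter) concerns configuration alone, and an 80-fold higher number from compound 1 to compound 3 (1.90 log units; beyond the scatter) concerns removal of a methoxy group, which compound 4 keeps. No step beyond the scatter is therefore expected for the ring exchange, and the step from compound 3 is estimated as a 1.1-fold lower number from compound 3 to compound 4 (0.04 log units; within the scatter). Compound 4 is expected to give 8000 nM in this assay, within 2500 nM to 25000 nM.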

Compound 4, half-maximal inhibitory concentration: 180 nM
The estimate for compound 4 lay 44-fold (1.65 log units) above the measured number, outside the stated range (below it).
By their numbers in this assay, from the lowest: compounds 1 and 4 (each within the scatter of the next); then compound 3.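

In this assay, the aromatic group on the saturated chain carbon, two bonds along the chain from a saturated ring carbon, responds strongly to the ring itself and not only to the number of methoxy groups: the exchange of 3-methoxyphenyl for 6-methoxypyridin-3-yl gives a 49-fold lower number from compound 3 to compound 4 (1.69 log units; beyond the scatter). Going by these compounds alone, a single methoxy group is therefore compatible with a low number at this position, as compound 4 gives 180 nM, whereas the single methoxy group of compound 3 alone did not suggest this. No measured property shown here bears on the reason for this step.

The exchange alters the ring atoms and the placement of the methoxy group together, so their shares in the step remain unseparated. A 4-methoxyphenyl group at this chain carbon would separate them, and a 6-aminopyridin-3-yl group would test whether the methoxy group itself matters.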